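Working notes on compound 3 and the step to compound 4

The source may report more compounds than this note shows. Statements on the series, on what has been measured and on what is new or still open speak of the compounds shown alone.

Of the compounds shown here, three have been tested in a functional assay on KYSE-70 cells for antiproliferative activity against KYSE-70 cell line (Homo sapiens), read by MTT assay, with a stated time of 72 h; a lower number here means a stronger inhibitor, a higher number a weaker inhibitor. Compound 1 `O=C(Nc1cccc(OC(F)(F)F)c1)c1cc(=O)[nH]c2cc(Br)ccc12` is reported only as a limit of the assay, > 20000 nM, and not as a number. Compound 2 `COc1ccc2c(C(=O)Nc3cc(F)cc(F)c3)cc(=O)[nH]c2c1` is likewise reported only as a limit, > 20000 nM. Going by the values given here, compound 3 `O=C(Nc1cccc(F)c1)c1cc(=O)[nH]c2cc(-c3ccc(F)cc3)ccc12` is the one compound with a number: in this assay compound 3 gives 3300 nM. Among the compounds with values here, compound 3 therefore stands as the only measured value in the set, the other two results sitting at the limit described by the limit of > 20000 nM in this assay, at which 2 of the 3 values shown sit. Within the data shown here, no pair of measured compounds differs in a single place, so nothing measured tells how any one change moves the read-out.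

Compound 4 `C=Cc1ccc2c(C(=O)Nc3cccc(F)c3)cc(=O)[nH]c2c1` is not yet measured. It differs from compound 3 in one place: vinyl in place of 4-fluorophenyl on an aromatic carbon. Among the measured compounds shown here, with no measured step to draw on, and with two of three results at the limit, the expectation for compound 4 in this assay is a loss of potency beyond the usual scatter, a 2.4-fold higher number from compound 3 to compound 4 (0.38 log units; beyond the scatter). Compound 4 is estimated at 8000 nM, with a range from 2500 nM to 20000 nM, and a fair chance that only a limit is reported.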

Compound 4, half-maximal inhibitory concentration: 9700 nM
Estimate against measurement, compound 4: 1.2-fold (0.08 log units) below; the measured number falls inside the stated range.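

In this assay the series now has its first reading of a single change, a modest loss of potency that lies beyond the scatter: a 2.9-fold higher number from compound 3 to compound 4 (0.47 log units; beyond the scatter). Compound 4 still gives a number, 9700 nM, so on this aromatic carbon, para to a fused ring, the 4-fluorophenyl group with its ring and 7 heavy atoms can give way to vinyl, with 2 heavy atoms and no ring, and the assay still returns a measured result. Compound 1 and compound 2 remain limits and not numbers, and neither differs from compound 3 or compound 4 in only one place, so they add no step: the limit of > 20000 nM in this assay, at which 2 of the 4 values shown sit.

This one step changes the ring, the fluorine and the size of the group together, so it cannot say which of these accounts for the shift. Going by these compounds, how an amine, a carboxylic acid, a plain phenyl or a longer alkyl chain would read on the same carbon stays open, as does whether anything there can bring the number below that of compound 3, 3300 nM.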